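The compounds below may be only part of what the source reports. "The series", "measured", "known", "first", "only" and "open" are said of these compounds alone.

In a functional assay on HL-60 cells (Homo sapiens) for inhibition, read by MTT assay, with a stated time of 72 h (a lower number here means a stronger inhibitor, a higher number a weaker inhibitor), three relatives have been measured so far. Compound 1 `Cc1nc(-c2cccc(F)c2)c(C(=O)N2CCN(c3cccc(Cl)c3)CC2)o1` shows 33.7 nM as its half-maximal inhibitory concentration. Compound 2 `Cc1ccc(C)c(N2CCN(C(=O)c3oc(C)nc3-c3cccc(Cl)c3)CC2)c1` shows 345 nM on the same read-out. Compound 3 `Cc1ccc(C)c(N2CCN(C(=O)c3oc(C)nc3-c3ccc(Cl)cc3)CC2)c1` comes out as "not active" (no number reported) and so has no number at all, which leaves no measured point from which to count a step.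

Compound 4 `Cc1ccc(C)c(N2CCN(C(=O)c3oc(C)nc3-c3cccc(F)c3)CC2)c1` changes one group on the shared core: 3-fluorophenyl in place of 4-chlorophenyl on an aromatic carbon next to the ring nitrogen 3-fluorophenyl in place of 4-chlorophenyl on an aromatic carbon with the rest left as it was. In this assay compound 4 is expected to move away from the reading of compound 3 toward a measurable number, although the size of that step cannot be stated. This expectation rests on compound 2 at 345 nM as the nearest measured relative and on compound 1 at 33.7 nM as the one carrying the same 3-fluorophenyl group. Compound 4 is estimated at 300 nM with an expected range of 80 nM to 1200 nM on that read-out.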

Compound 4, half-maximal inhibitory concentration: 204 nM
Compound 4: middle estimate off by 1.5-fold (0.17 log units), on the high side; low and high end bracket the measured number.
By their numbers in this assay, from the lowest: compound 1; then compounds 4 and 2 (each within the scatter of the next).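

In this assay, with the 3-fluorophenyl group in this position, the shift of fluoro in place of chloro on an aromatic carbon gives a 1.7-fold lower number from compound 2 to compound 4 (0.23 log units; within the scatter) and so leaves the reading essentially unchanged. With that same group held fixed, 2,5-dimethylphenyl in place of 3-chlorophenyl on the ring amine nitrogen gives a 6.1-fold higher number from compound 1 to compound 4 (0.78 log units; beyond the scatter), a modest step that is larger than the scatter. Compound 3 has no number, so the step from it to compound 4 cannot be read, and no measurement shown offers a reason for either readable step.

From the compounds shown here alone, whether a 4-fluorophenyl group would read as a number or as not active stays open. So does how a methoxy group, a nitrile or an amine on this phenyl ring would read.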